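Swapping the Sulfonamide Headgroup in Two Paired Compounds

The source may report more compounds than this note shows. Statements on the series, on what has been measured and on what is new or still open speak of the compounds shown alone.

Compound 1, `Cc1cc(NS(=O)(=O)c2ccc(NCc3coc4ccccc4c3=O)cc2)no1`, in a functional assay on MCF7 cells (Homo sapiens) for cytotoxicity, read by sulforhodamine B assay, with a stated time of 72 h; a higher number here means a weaker inhibitor, a lower number a stronger inhibitor: 34500 nM.
Compound 2, `Cc1cc(C)nc(NS(=O)(=O)c2ccc(NCc3coc4ccccc4c3=O)cc2)n1`, in this assay: 93600 nM.
Compound 3, `Cc1cc(C)nc(NS(=O)(=O)c2ccc(NC3=NC(=O)/C(=C\c4coc5ccccc5c4=O)S3)cc2)n1`, in this assay: only a limit, > 100000 nM.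

Compounds 1 and 2 share one core and differ in a single place, the group on the sulfonamide nitrogen: 5-methyl-1,2-oxazol-3-yl in place of 4,6-dimethylpyrimidin-2-yl on a sulfonamide nitrogen. That exchange produced a 2.7-fold lower number from compound 2 to compound 1 (0.43 log units; beyond the scatter), a step that lies beyond the usual scatter of repeated measurements.

Compound 3 carries a different core; the difference between the two cores is not broken down here. For compound 3 the result in this assay is a limit of the assay rather than a number (the limit of > 100000 nM in this assay, at which 1 of the 3 values shown sits).

Compound 4, `Cc1cc(NS(=O)(=O)c2ccc(NC3=NC(=O)/C(=C\c4coc5ccccc5c4=O)S3)cc2)no1`, has not yet been measured. It stands to compound 3 as compound 1 stands to compound 2: 5-methyl-1,2-oxazol-3-yl in place of 4,6-dimethylpyrimidin-2-yl on a sulfonamide nitrogen, the same change at the same place. Among the measured compounds shown here, the step from compound 3 to compound 4 is expected to be about an at least 1.2-fold lower number from compound 3 to compound 4 (0.09 log units; that floor lies within the scatter), an expectation resting on the one measured instance, a 2.7-fold lower number from compound 2 to compound 1 (0.43 log units; beyond the scatter). Because compound 3 shows only the limit > 100000 nM, the starting point of that step is itself uncertain. Compound 4 is therefore estimated at 80000 nM in this assay. The likely range for compound 4 is expected to run from 30000 nM to 300000 nM.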

Compound 4, half-maximal inhibitory concentration: > 100000 nM
Compound 4: a limit, no number (the forecaster's own chance of this, stated with the estimate: 45%); middle value at least 1.2-fold (0.09 log units) away from the limit.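

Compound 3 and compound 4 both sit at a limit of this assay rather than at a number, so the step between them cannot be read: the limit of > 100000 nM in this assay, at which 2 of the 4 values shown sit.

On these data alone, whether 5-methyl-1,2-oxazol-3-yl in place of 4,6-dimethylpyrimidin-2-yl, which separates compound 1 from compound 2, changes anything on the core of compound 3 and compound 4 stays open, as does the true potency of these two compounds.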